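Aryl exchange on the shared core: compound 3 to compound 4

This account rests on a few compounds, and the source may have more. Where it says the series, first, only, none or still open, it means among the compounds named here.

Three analogues on the shared core have numbers in a functional assay on LNCaP cells (Homo sapiens) for cytotoxicity, read by MTT assay, with a stated time of 48 h; on this read-out lower numbers stand for stronger inhibition and higher numbers for weaker inhibition. Compound 1 `c1ccc(-c2nc(-c3c[nH]c4ccccc34)co2)cc1` gives 461000 nM, compound 2 `Cc1nc(-c2c[nH]c3ccccc23)co1` gives 316000 nM, and compound 3 `Fc1ccc(-c2nc(-c3c[nH]c4ccccc34)co2)cc1` gives 59800 nM. Compound 3 has the lowest number of the three: a 7.7-fold lower number from compound 1 to compound 3 (0.89 log units; beyond the scatter), and a 5.3-fold lower number from compound 2 to compound 3 (0.72 log units; beyond the scatter), both beyond the scatter, while a 1.5-fold lower number from compound 1 to compound 2 (0.16 log units; within the scatter) stays within it. Compound 4 `c1ccc2c(-c3coc(-c4ccncc4)n3)c[nH]c2c1` differs from compound 3 in one place: pyridin-4-yl in place of 4-fluorophenyl on an aromatic carbon. Within the data shown here, no measured step exchanges a 4-fluorophenyl for a pyridin-4-yl, so none bears on it directly; the nearest comparisons are the fluoro-for-hydrogen step, a 7.7-fold lower number from compound 1 to compound 3 (0.89 log units; beyond the scatter), and the 4-fluorophenyl-for-methyl step, a 5.3-fold lower number from compound 2 to compound 3 (0.72 log units; beyond the scatter), which show that what sits on this carbon moves this assay by modest amounts. With the fluorine leaving and a ring nitrogen entering, a modest rise in the number is expected for compound 4, a 2.5-fold higher number from compound 3 to compound 4 (0.40 log units; beyond the scatter). Compound 4 is therefore estimated at 150000 nM, within 40000 nM to 500000 nM.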

Compound 4, half-maximal inhibitory concentration: 238000 nM
For compound 4 the middle estimate is 1.6-fold (0.20 log units) below the measured one; low and high end bracket the measured number.
By their numbers in this assay, from the lowest: compound 3; then compounds 4, 2 and 1 (each within the scatter of the next).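

In this assay pyridin-4-yl does not reproduce the low number of 4-fluorophenyl at this carbon (a 4.0-fold higher number from compound 3 to compound 4 (0.60 log units; beyond the scatter)), so that number does not extend to every six-membered aromatic ring placed here. Pyridin-4-yl also stays within the scatter of both methyl (a 1.3-fold lower number from compound 2 to compound 4 (0.12 log units; within the scatter)) and phenyl (a 1.9-fold lower number from compound 1 to compound 4 (0.29 log units; within the scatter)), which leaves compound 3 as the only one of the four set apart beyond the scatter. Nothing available accounts for the difference between 4-fluorophenyl and pyridin-4-yl.

Going by these compounds, it remains open whether the lower number of compound 3 is specific to fluoro or would also appear with 4-chlorophenyl or 4-aminophenyl on this carbon. Also open, on these data alone, is whether a fluoro group on the pyridin-4-yl ring would bring compound 4 closer to compound 3.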